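A few compounds are considered here, and "the series" means these few. Any claim that something is new, unique, unknown or untested is made for them only; others in the source may bear on it.

Compound 1 `Cc1ccc(S(=O)(=O)Oc2ccccc2/C=C(\C#N)C(=O)Nc2nnc(Cc3ccccc3)s2)cc1`: 69%
Compound 2 `Cc1ccc(S(=O)(=O)Oc2ccccc2/C=C(\C#N)C(=O)Nc2nnc(Cc3cccc(F)c3)s2)cc1`: 56%

Among the measured compounds shown here, in a functional assay on RS4-11 cells (Homo sapiens) for inhibition, read by CCK-8 assay, with a stated time of 48 h, tested at 20 uM (a lower number here means less inhibition of growth, a higher number more inhibition of growth at the concentration tested), compound 2 gives 56%, the lower of the two numbers so far and beyond the scatter from compound 1. The next compound is compound 3 `Cc1ccc(S(=O)(=O)Oc2ccccc2/C=C(\C#N)C(=O)Nc2nnc(Cc3ccc(Cl)cc3)s2)cc1`, which carries 4-chlorophenyl in place of 3-fluorophenyl on a saturated chain carbon bound to an aromatic carbon.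

For the measured compounds named here, only one measured step bears on this change: a number 13 percentage points lower from compound 1 to compound 2 (beyond the scatter), a modest step with fluoro in place of hydrogen on an aromatic carbon. Going by the values given here, no compound with chlorine has been measured, so that step offers only a weak guide. Compound 3 lacks the fluoro, which leaves a small rise possible towards compound 1 at 69%. No change beyond the scatter is expected for compound 3, and the expected step is a number 4 percentage points higher from compound 2 to compound 3 (within the scatter). For compound 3 the estimated value is 60%, with an expected range of 42% to 78%.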

Compound 3, percent growth inhibition at one concentration: 69%
Compound 3: middle estimate off by 9 percentage points, on the low side; low and high end bracket the measured number.
By their numbers in this assay, from the lowest: compound 2; then compounds 1 and 3 (each within the scatter of the next).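

In this assay, among the compounds shown here, the earlier compounds showed only a fall with a halogen on this ring, but no change at the digits printed from compound 1 to compound 3 (within the scatter), so a halogen here does not by itself go with weaker growth inhibition. The other step, a number 13 percentage points higher from compound 2 to compound 3 (beyond the scatter), shows that 4-chlorophenyl and 3-fluorophenyl are not interchangeable on a saturated chain carbon bound to an aromatic carbon, and that the fall seen with 3-fluorophenyl does not extend to every halogen-bearing ring. No supporting data are available to explain this difference.

The halogen and its place on the ring change together from 3-fluorophenyl to 4-chlorophenyl, so the compounds shown cannot separate the two. Also open, on these data alone, is how an amine or a carboxylic acid on this ring, or a longer chain in place of the benzyl link, would read in this assay.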